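Ester-to-acid step on the oxazole side chain

The source may hold more compounds than are shown below. What is called first, only, known or untested is meant among the compounds shown, and "the series" means these compounds.

Among the compounds with values here, compound 3 `COC(=O)CCCCc1cnc(C(=O)CCCCCCc2ccccc2)o1` gives 1.8 nM in an assay for inhibition of Fatty-acid amide hydrolase 1 (Rattus norvegicus), using a Dixon plot; a higher number here means a weaker inhibitor, a lower number a stronger inhibitor; it holds the lowest of the three numbers so far. Compound 1 `O=Cc1ccc(-c2cnc(C(=O)CCCCCCc3ccccc3)o2)nc1` gives 2.2 nM, and compound 2 `CSCc1ccc(-c2cnc(C(=O)CCCCCCc3ccccc3)o2)nc1` gives 11.1 nM. The steps from compound 1 to compound 3 a 1.2-fold lower number from compound 1 to compound 3 (0.09 log units; within the scatter) and from compound 2 to compound 3 a 6.2-fold lower number from compound 2 to compound 3 (0.79 log units; beyond the scatter) both brought in the methoxycarbonyl chain; the step of a 5.0-fold higher number from compound 1 to compound 2 (0.70 log units; beyond the scatter) changed a group on an aromatic carbon. Compound 4 `O=C(O)CCCCc1cnc(C(=O)CCCCCCc2ccccc2)o1` differs from compound 3 by hydrogen in place of methyl on an oxygen next to a carbonyl group. Within the data shown here, no measured step touches this oxygen, so nothing here speaks for a large move in this assay; a change within the scatter or a small rise is expected, a 2.2-fold higher number from compound 3 to compound 4 (0.35 log units; beyond the scatter). Compound 4 is estimated at 4 nM, between 1 nM and 20 nM.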

Compound 4, inhibition constant: 23.8 nM
Compound 4: the middle estimate sits 6.0-fold (0.77 log units) below what was measured, outside the stated range (above it).
By their numbers in this assay, from the lowest: compounds 3 and 1 (each within the scatter of the next); then compound 2; then compound 4.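

In this assay, within the data shown here, the methoxycarbonyl to carboxy change gives the first measured step at this oxygen, and it is large (a 13-fold higher number from compound 3 to compound 4 (1.12 log units; beyond the scatter)). The carboxy chain also falls behind both aromatic-ring groups (an 11-fold higher number from compound 1 to compound 4 (1.03 log units; beyond the scatter); a 2.1-fold higher number from compound 2 to compound 4 (0.33 log units; beyond the scatter)), whereas the methoxycarbonyl chain stays within the scatter of the formyl compound. No available evidence accounts for the loss.

From the compounds shown here alone, it remains open whether the ester's methyl is specifically needed or any capped carbonyl would serve. An ethyl ester or a primary amide on the same chain would test this.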